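Swapping the aryl on the pyrrole nitrogen for benzyl

This account rests on a few compounds, and the source may have more. Where it says the series, first, only, none or still open, it means among the compounds named here.

Compound 2 `CCOC(=O)C1=C(C)N/C(=C/c2cc(C)n(-c3ccncc3)c2C)C1=O` gives 100000 nM in an ADME assay on L6 cells (Rattus norvegicus) for cytotoxicity, read by resazurin assay, with a stated time of 72 h (on this read-out lower numbers stand for an effect already at smaller amounts and higher numbers for an effect only at larger amounts of compound), level with compound 1 `CCOC(=O)C1=C(C)N/C(=C/c2cc(C)n(-c3ccc(Br)cc3)c2C)C1=O`, which gives 100000 nM. For the measured compounds named here, the one step measured so far, no change at the digits printed from compound 1 to compound 2 (within the scatter), left the read-out unchanged within the scatter. Compound 3 `CCOC(=O)C1=C(C)N/C(=C/c2cc(C)n(Cc3ccccc3)c2C)C1=O` differs from compound 2 by benzyl in place of pyridin-4-yl on an aromatic nitrogen. Since the exchange of the group on the aromatic nitrogen in no change at the digits printed from compound 1 to compound 2 (within the scatter) moved nothing, compound 3 is expected to stay where compound 2 stands, with no step beyond the scatter, no change at the digits printed from compound 2 to compound 3 (within the scatter). The estimate for compound 3 is therefore 100000 nM, ranging from 35000 nM to 200000 nM.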

Compound 3, half-maximal effective concentration: 50000 nM
Compound 3: the middle estimate sits 2.0-fold (0.30 log units) above what was measured; the measured number falls inside the stated range.
By their numbers in this assay, from the lowest: compounds 3, 1 and 2 (each within the scatter of the next).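

For the compounds shown here, with benzyl on the aromatic nitrogen, the first group here whose aromatic ring is not bonded directly to that nitrogen, the compounds show a 2.0-fold lower number from compound 2 to compound 3 (0.30 log units; within the scatter) and a 2.0-fold lower number from compound 1 to compound 3 (0.30 log units; within the scatter) in this assay for this change. This position has therefore carried 4-bromophenyl, pyridin-4-yl and benzyl with no step beyond the scatter. Nothing available bears on the reason for this result.

The compounds shown leave open whether an amine, a carboxylic acid or a longer alkyl chain on that nitrogen would also stay within the scatter.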